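Thiophene Attachment Shifted on the Shared Core

The source may hold more compounds than are shown below. What is called first, only, known or untested is meant among the compounds shown, and "the series" means these compounds.

Among the compounds with values here, in a functional assay on DU-145 cells (Homo sapiens) for cytotoxicity, read by ELISA, with a stated time of 2 days (a higher number here means a weaker inhibitor, a lower number a stronger inhibitor), compound 1 `Oc1ccc(-c2cc(-c3ccccc3)cc(-c3ccccc3)n2)cc1` gives 3000 nM and compound 2 `Oc1ccc(-c2cc(-c3ccccc3)cc(-c3cccs3)n2)cc1` gives 3700 nM, so compound 2 stands level with its only neighbour. Compound 3 `Oc1ccc(-c2cc(-c3ccccc3)cc(-c3ccsc3)n2)cc1` has the same atoms joined differently: thiophen-3-yl in place of thiophen-2-yl on an aromatic carbon, with thiophen-3-yl in place of thiophen-2-yl on an aromatic carbon next to the ring nitrogen. Within the data shown here, the one measured step, a 1.2-fold higher number from compound 1 to compound 2 (0.09 log units; within the scatter), exchanged phenyl for thiophen-2-yl and stayed within the scatter, so no shift beyond the scatter is expected in this assay. The expected step, a 1.1-fold lower number from compound 2 to compound 3 (0.04 log units; within the scatter), is correspondingly small. Compound 3 is estimated at 3400 nM, within a range of 1700 nM to 6500 nM.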

Compound 3, half-maximal inhibitory concentration: 8500 nM
Beside the measured number, compound 3's estimate is 2.5-fold (0.40 log units) below it, and the stated range ends below it.
By their numbers in this assay, from the lowest: compounds 1 and 2 (each within the scatter of the next); then compound 3.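

In this assay the position next to the ring nitrogen proves sensitive to how the thiophene is attached, with the shift from thiophen-2-yl to thiophen-3-yl showing a 2.3-fold higher number from compound 2 to compound 3 (0.36 log units; beyond the scatter) and the exchange of phenyl for thiophen-3-yl showing a 2.8-fold higher number from compound 1 to compound 3 (0.45 log units; beyond the scatter) as modest steps beyond the scatter. The earlier exchange of phenyl for thiophen-2-yl had stayed within the scatter, so the same atoms joined differently separate here. Nothing available explains this difference. From the compounds shown here alone, whether an amine or a carboxylic acid at this position would give a lower number than phenyl remains open.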